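Swapping 4-hydroxy-2-methylphenyl for 4-ethylphenyl

The compounds below may be only part of what the source reports. "The series", "measured", "known", "first", "only" and "open" are said of these compounds alone.

Measured in a functional assay on HCC 2998 cells (Homo sapiens) for inhibition, read by sulforhodamine B assay, with a stated time of 48 h; on this read-out lower numbers stand for stronger inhibition of growth and higher numbers for weaker inhibition of growth
Compound 1 `Cc1ccc(C2=NN(c3ccc(S(C)(=O)=O)cc3)C(=O)CC2)cc1` gives 2750 nM
Compound 2 `Cc1cc(O)ccc1C1=NN(c2ccc(S(C)(=O)=O)cc2)C(=O)CC1` gives 46700 nM

Compound 2 at 46700 nM stands highest of the two numbers. Compound 3 `CCc1ccc(C2=NN(c3ccc(S(C)(=O)=O)cc3)C(=O)CC2)cc1` differs from it by 4-ethylphenyl in place of 4-hydroxy-2-methylphenyl on a carbon with a double bond to nitrogen with 4-ethylphenyl in place of 4-hydroxy-2-methylphenyl on a carbon with a double bond to nitrogen. For the measured compounds named here, putting 4-hydroxy-2-methylphenyl in place of 4-methylphenyl gave a 17-fold higher number from compound 1 to compound 2 (1.23 log units; beyond the scatter) and that large step is the one measured change bearing on this. A large step to a lower number, beyond the scatter, is therefore expected in this assay and compound 1 at 2750 nM is the nearest guide, although 4-ethylphenyl itself is unmeasured. The expected step is a 16-fold lower number from compound 2 to compound 3 (1.19 log units; beyond the scatter) in size. The expected value for compound 3 is 3000 nM with 1000 nM to 9000 nM as its range.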

Compound 3, concentration for 50% growth inhibition: 5270 nM
For compound 3 the middle estimate is 1.8-fold (0.24 log units) below the measured one; measured number inside the range.
By their numbers in this assay, from the lowest: compounds 1 and 3 (each within the scatter of the next); then compound 2.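

In this assay, 4-ethylphenyl in place of 4-hydroxy-2-methylphenyl gives an 8.9-fold lower number from compound 2 to compound 3 (0.95 log units; beyond the scatter), so a group on this carbon can restore the level of compound 1. Methyl in place of hydrogen on the saturated chain carbon gives a 1.9-fold higher number from compound 1 to compound 3 (0.28 log units; within the scatter), so this small extension of the chain leaves the read-out within the scatter. Nothing measured here accounts for the gap between these groups.

The compounds shown leave open whether the hydroxy or the added methyl of 4-hydroxy-2-methylphenyl goes with the higher number. They also leave open how a propyl chain or an amine would read at this position.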